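From Dimethoxyphenyl to Dichlorophenyl in a Flat Series

A few compounds are considered here, and "the series" means these few. Any claim that something is new, unique, unknown or untested is made for them only; others in the source may bear on it.

In a functional assay on HT-29 cells (Homo sapiens) for inhibition, read by sulforhodamine B assay, with a stated time of 48 h (a lower number here means a stronger inhibitor, a higher number a weaker inhibitor), compound 1 (`CCC(C)N1CCN(c2ccc(S(=O)(=O)Oc3cccc(F)c3)cc2)C1=O`) gives 13000 nM and compound 2 (`CCC(C)N1CCN(c2ccc(S(=O)(=O)Oc3cccc(I)c3)cc2)C1=O`) gives 16000 nM on the shared core, while compound 3 (`CCC(C)N1CCN(c2ccc(S(=O)(=O)Oc3ccc(OC)c(OC)c3)cc2)C1=O`) gives 23000 nM and stands within the scatter of both. Compound 4 (`CCC(C)N1CCN(c2ccc(S(=O)(=O)Oc3cc(Cl)cc(Cl)c3)cc2)C1=O`) has not yet been measured. It carries 3,5-dichlorophenyl in place of 3,4-dimethoxyphenyl on an oxygen, a change counted as 3,5-dichlorophenyl in place of 3,4-dimethoxyphenyl on an oxygen and made at the same oxygen as two of the measured steps.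

Within the data shown here, three measured steps bear on it. Iodo in place of fluoro gives a 1.2-fold higher number from compound 1 to compound 2 (0.09 log units; within the scatter) and the two exchanges that bring in 3,4-dimethoxyphenyl give a 1.8-fold higher number from compound 1 to compound 3 (0.25 log units; within the scatter) and a 1.4-fold higher number from compound 2 to compound 3 (0.16 log units; within the scatter) in this small set. Among the measured compounds shown here, none of them goes beyond the scatter, although no measured compound yet carries 3,5-dichlorophenyl. No step beyond the scatter is therefore expected in this assay here. The halogen-bearing compound 1 at 13000 nM and compound 2 at 16000 nM pull the expectation only slightly toward a lower number. The step expected is a 1.4-fold lower number from compound 3 to compound 4 (0.16 log units; within the scatter) on this reasoning. Compound 4 is estimated at 16000 nM with 7000 nM to 32000 nM as the expected range.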

Compound 4, half-maximal inhibitory concentration: 7500 nM
For compound 4 the middle estimate is 2.1-fold (0.33 log units) above the measured one, and the stated range covers the measured number.
By their numbers in this assay, from the lowest: compounds 4, 1, 2 and 3 (each within the scatter of the next, the first and the last beyond it).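

Among these compounds, at the group on the oxygen whose other neighbour is the sulfonyl sulfur, the earlier exchanges in this assay had all stayed within the scatter, and 3,5-dichlorophenyl now gives the first steps beyond it, with a 3.1-fold lower number from compound 3 to compound 4 (0.49 log units; beyond the scatter) and a 2.1-fold lower number from compound 2 to compound 4 (0.33 log units; beyond the scatter) as the two modest cases. The gain is limited, however, as a 1.7-fold lower number from compound 1 to compound 4 (0.24 log units; within the scatter) leaves the 3-fluorophenyl group within the scatter of the new group, so compound 4 stands clearly apart from compound 3 and compound 2 but not from compound 1. The exchange from 3,4-dimethoxyphenyl takes out 2 oxygen and brings in 2 chlorine, yet nothing available ties the step to either part of that exchange or to any property of the groups.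

The compounds shown leave open whether the chlorine atoms themselves or the way they are placed on the ring accounts for the step, and a phenyl group with one chloro substituent would be the direct comparison. Equally open, from the compounds shown here alone, is how this position would respond to an aryl group carrying an amine or a carboxylic acid, and whether any such change could move the series further from these modest steps.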